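A few compounds are considered here, and "the series" means these few. Any claim that something is new, unique, unknown or untested is made for them only; others in the source may bear on it.

Of the compounds shown here, three sharing one core have been measured so far in an assay on isolated protein for inhibition of 15-hydroxyprostaglandin dehydrogenase [NAD(+)] (Homo sapiens), read by fluorescence, with a stated time of 15 min; a lower number here means a stronger inhibitor, a higher number a weaker inhibitor. Compound 1 `Cc1cccc(-n2cnc3cc(C(=O)N4CCC(Br)CC4)ccc32)c1` carries a 4-bromopiperidin-1-yl group on its carbonyl carbon and gives 76 nM. Compound 2 `Cc1cccc(-n2cnc3cc(C(=O)N4CCCC4)ccc32)c1` carries a pyrrolidin-1-yl group there and gives 383 nM, a change of a 5.0-fold higher number from compound 1 to compound 2 (0.70 log units; beyond the scatter). Compound 3 `CCCCNC(=O)c1ccc2c(c1)ncn2-c1cccc(C)c1` carries an open butylamino group on that carbonyl carbon and gives 1360 nM; it stands highest of the three, which in this assay means the weakest inhibitor, with steps of an 18-fold higher number from compound 1 to compound 3 (1.25 log units; beyond the scatter) and a 3.6-fold higher number from compound 2 to compound 3 (0.55 log units; beyond the scatter) separating it from the two others.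

Compound 4 `Cc1cccc(-n2cnc3cc(C(=O)N4CCOCC4)ccc32)c1` has not yet been measured. The change from compound 3 is morpholin-4-yl in place of butylamino on a carbonyl carbon. The two steps that bear on it are those ending at compound 3, both of which show that the two groups whose nitrogen sits in a ring give lower numbers than the open butylamino group. Morpholin-4-yl also places its nitrogen in a ring, so a lower number, beyond the scatter, is expected, close to what compound 2 shows. The estimated step is a 3.9-fold lower number from compound 3 to compound 4 (0.59 log units; beyond the scatter). For compound 4 the estimated value in this assay is 350 nM, with a range from 120 nM to 1000 nM.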

Compound 4, half-maximal inhibitory concentration: 3040 nM
Beside the measured number, compound 4's estimate is 8.7-fold (0.94 log units) below it, outside the stated range (above it).
By their numbers in this assay, from the lowest: compound 1; then compound 2; then compound 3; then compound 4.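

Putting the nitrogen in a ring does not by itself give a stronger inhibitor at this carbonyl carbon: morpholin-4-yl in place of butylamino gives a 2.2-fold higher number from compound 3 to compound 4 (0.35 log units; beyond the scatter) and so a weaker inhibitor, although the ring groups of compound 1 and compound 2 both gave stronger inhibitors than butylamino. Ring groups also differ widely among themselves, with a 7.9-fold higher number from compound 2 to compound 4 (0.90 log units; beyond the scatter) and a 40-fold higher number from compound 1 to compound 4 (1.60 log units; beyond the scatter) making compound 4 the weakest inhibitor of the four, so the identity of the ring matters and not merely its presence. Nothing available here accounts for this order.

Within the data shown here, the four compounds cannot show whether the loss follows the oxygen of the morpholine ring, since morpholin-4-yl is the only group among them that carries one, and a plain piperidin-1-yl group would compare directly with both compound 4 and compound 1. Going by these compounds, it also remains open how a piperazin-1-yl group, with a second nitrogen in that ring position, or a shorter or longer open chain than butylamino would rank against these four.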